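Butyl on the carboxy oxygen: expected recovery of inhibition

The compounds below may be only part of what the source reports. "The series", "measured", "known", "first", "only" and "open" are said of these compounds alone.

Measured in a functional assay on MOLT-4 cells (Homo sapiens); on this read-out lower numbers stand for stronger inhibition and higher numbers for weaker inhibition:
- compound 1 `NC(=O)c1nn([C@@H]2O[C@H](CO)[C@@H](O)[C@H]2O)cc1I` gives 9100 nM
- compound 2 `COC(=O)c1nn([C@@H]2O[C@H](CO)[C@@H](O)[C@H]2O)cc1I` gives 900 nM
- compound 3 `O=C(O)c1nn([C@@H]2O[C@H](CO)[C@@H](O)[C@H]2O)cc1I` gives > 300000 nM, a limit

Compound 3 stands at the limit of > 300000 nM in this assay, at which 1 of the 3 values shown sits, which is a limit and not a number. Compound 4 `CCCCOC(=O)c1nn([C@@H]2O[C@H](CO)[C@@H](O)[C@H]2O)cc1I` carries butyl in place of hydrogen on an oxygen next to a carbonyl group, which reads as carboxy to butoxycarbonyl.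

The closest evidence is an at least 330-fold higher number from compound 2 to compound 3 (2.52 log units; beyond the scatter), where hydrogen replaces methyl on that same oxygen. The change an at least 32-fold higher number from compound 1 to compound 3 (1.51 log units; beyond the scatter) also marks the carboxy compound as far weaker. Read in reverse, these large steps lead to the expectation of a large step toward lower numbers in this assay, although no measured compound bears butyl. The anchor is compound 2 at 900 nM. The expected step is an at least 300-fold lower number from compound 3 to compound 4 (2.47 log units; beyond the scatter). For compound 4 the estimated value is 1000 nM, with an expected range of 200 nM to 6000 nM.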

Compound 4, half-maximal inhibitory concentration: 16000 nM
Compound 4: middle estimate off by 16-fold (1.20 log units), on the low side, and the stated range ends below it.
By their numbers in this assay, from the lowest: compound 2; then compounds 1 and 4 (each within the scatter of the next). At a limit, above all of these: compound 3.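

In this assay compound 3 is a limit and not a number: the limit of > 300000 nM in this assay, at which 1 of the 4 values shown sits. Carboxy to butoxycarbonyl still gives an at least 18-fold lower number from compound 3 to compound 4 (1.27 log units; beyond the scatter), so the gain on capping this oxygen is not confined to methyl. The size of the group on this oxygen nevertheless matters, with the extension from methyl to butyl giving an 18-fold higher number from compound 2 to compound 4 (1.25 log units; beyond the scatter), while butoxy in place of amino on the carbonyl carbon gives a 1.8-fold higher number from compound 1 to compound 4 (0.25 log units; within the scatter), which places the butyl ester and the amide within the scatter of each other.

The ethyl and propyl esters would show whether the rise between methyl and butyl runs steadily along the chain or appears at one length. From the compounds shown here alone, a branched isopropyl ester or a benzyl ester remains open, as does a methylamide on the amide side.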